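A Heteroaryl Swap Judged From Three Measured Analogues

This account rests on a few compounds, and the source may have more. Where it says the series, first, only, none or still open, it means among the compounds named here.

Three compounds share one core. Compound 1 `Cc1csc(-c2nc(N)c3cc(Cc4ccccc4)sc3n2)n1` gives 1490 nM in a functional assay on CHO-K1 cells for antagonist activity at adenosine receptor A1 (Homo sapiens), read by a beta-galactosidase reporter and cAMP accumulation, with stated times of 15 min and 6 h; on this read-out lower numbers stand for stronger inhibition and higher numbers for weaker inhibition. Compound 2 `Cc1csc(-c2nc(N)c3cc(Cc4ccccc4F)sc3n2)n1` gives 28.6 nM, and compound 3 `Cn1cnc(-c2nc(N)c3cc(Cc4ccccc4)sc3n2)c1` gives 2330 nM. Compound 3 holds the highest of the three numbers; compound 1 stands nearest, since a 1.6-fold higher number from compound 1 to compound 3 (0.19 log units; within the scatter) lies within the scatter, while compound 2 stands furthest, beyond the scatter. Compound 4 `N#Cc1cccc(-c2nc(N)c3cc(Cc4ccccc4)sc3n2)n1` differs from compound 3 by 6-cyanopyridin-2-yl in place of 1-methyl-1H-imidazol-4-yl on an aromatic carbon. The step that bears on this is the earlier heteroaryl exchange, a 1.6-fold higher number from compound 1 to compound 3 (0.19 log units; within the scatter), which stayed within the scatter; the large 52-fold lower number from compound 1 to compound 2 (1.72 log units; beyond the scatter) concerns a different change and says nothing here. A small shift is therefore expected, a 1.5-fold lower number from compound 3 to compound 4 (0.16 log units; within the scatter), with no direction beyond the scatter. Compound 4 is estimated at 1600 nM, within 400 nM to 6500 nM.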

Compound 4, inhibition constant: > 1000 nM
Compound 4 was reported as a limit; the forecaster's own chance of this, stated with the estimate: 10%; the middle value is on the limit's open side.
By their numbers in this assay, from the lowest: compound 2; then compounds 1 and 3 (each within the scatter of the next).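

Compound 4 gives > 1000 nM in this assay, which is a limit and not a number. Its steps from compound 1 and compound 3 therefore cannot be read. The compounds shown leave open how the 6-cyanopyridin-2-yl group of compound 4 compares with the groups it replaces.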